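The source may report more compounds than this note shows. Statements on the series, on what has been measured and on what is new or still open speak of the compounds shown alone.

Measured so far:
compound 1 `CS(=O)(=O)c1ccc(C(=O)NCCC(=O)N2CCCCC2)cc1[N+](=O)[O-]`: in an ADME assay on HepG2 cells (Homo sapiens) for cytotoxicity, read by CellTiter-Glo and ATP content, with a stated time of 72 h (on this read-out lower numbers stand for an effect already at smaller amounts and higher numbers for an effect only at larger amounts of compound), compound 1 gives > 27000 nM, which is a limit of the assay.
compound 2 `CS(=O)(=O)c1ccc(C(=O)NCCC(=O)N2CCc3ccccc32)cc1[N+](=O)[O-]`: in this assay compound 2 gives > 27000 nM, which is a limit of the assay.

Compound 2 therefore stands only at a limit in this assay. Among the compounds with values here, every value shown is a limit, so no order among the compounds is readable. Compound 3 `CC1CCN(C(=O)CCNC(=O)c2ccc(S(C)(=O)=O)c([N+](=O)[O-])c2)CC1` differs from compound 2 by 4-methylpiperidin-1-yl in place of 2,3-dihydro-1H-indol-1-yl on a carbonyl carbon. Within the data shown here, the one measured step, a step that the two limits leave unreadable from compound 1 to compound 2, also swaps the group on that carbonyl carbon, but the limit of > 27000 nM in this assay, at which 2 of the 2 values shown sit, leaves its size unreadable. No step beyond the scatter is expected for a step that the limit leaves unreadable from compound 2 to compound 3. Compound 3 is expected at 50000 nM, range 20000 nM to 150000 nM, most likely reported again only as a limit.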

Compound 3, half-maximal effective concentration: > 27000 nM
Compound 3 gave a limit, no number (the forecaster's own chance of this, stated with the estimate: 85%); the middle value does not contradict the limit.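

No step can be read among compound 1, compound 2 and compound 3 in this assay, since all three sit at the same limit: the limit of > 27000 nM in this assay, at which 3 of the 3 values shown sit.

The compounds shown leave open whether the group on the carbonyl carbon matters at all in this assay.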